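Ester variation on a glycosylated core: limits so far

The compounds below may be only part of what the source reports. "The series", "measured", "known", "first", "only" and "open" are said of these compounds alone.

Measured so far
compound 1 `C/C=C1/[C@H](O[C@@H]2O[C@H](CO)[C@@H](O)[C@H](O)[C@H]2O)OC=C(C(=O)OC)[C@H]1CC(=O)OCC`: > 15000 nM
compound 2 `C/C=C1/[C@H](O[C@@H]2O[C@H](COC(C)=O)[C@@H](OC(C)=O)[C@H](OC(C)=O)[C@H]2OC(C)=O)OC=C(C(=O)OC)[C@H]1CC(=O)SCCC`: > 15000 nM

In a functional assay on SK-BR-3 cells (Homo sapiens) for antiproliferative activity, read by MTT assay, with a stated time of 72 h (on this read-out higher numbers stand for weaker inhibition and lower numbers for stronger inhibition), compound 1 reaches only a limit, > 15000 nM. Compound 2 likewise stops at a limit in this assay, > 15000 nM. Both readings sit on (the limit of > 15000 nM in this assay, at which 2 of the 2 values shown sit), so compound 1 has no measured position within the range, only a floor on weak inhibition.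

Compound 3 `C/C=C1/[C@H](O[C@@H]2O[C@H](CO)[C@@H](O)[C@H](O)[C@H]2O)OC=C(C(=O)OC)[C@H]1CC(=O)OCc1ccc(OC)c(OC)c1` differs from compound 1 by 3,4-dimethoxyphenyl in place of methyl on a saturated chain carbon bound to an oxygen next to a carbonyl group. Going by the values given here, no measured step covers this change. The expected step from compound 1 to compound 3 in this assay is a number no higher from compound 1 to compound 3 (the limit leaves the size open), not beyond the scatter. Compound 3 is therefore estimated at 15000 nM, expected between 5000 nM and 40000 nM.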

Compound 3, half-maximal inhibitory concentration: > 15000 nM
Compound 3: no number, only a limit (the forecaster's own chance of this, stated with the estimate: 65%); the middle value sits exactly at the limit.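

Going by these compounds alone, compound 1 and compound 3 both stop at a limit in this assay and no step between them can be read: the limit of > 15000 nM in this assay, at which 3 of the 3 values shown sit. From the compounds shown here alone, whether 3,4-dimethoxyphenyl in place of methyl changes inhibition at all stays open.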